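A cyclopropyl swap at the limit of tolerance

This account rests on a few compounds, and the source may have more. Where it says the series, first, only, none or still open, it means among the compounds named here.

Compound 1 `COc1ccc(Cn2c(C(=O)N3CCCC3)cc3sccc32)cc1`: > 100000 nM, a limit
Compound 2 `COc1ccc(Cn2c(C(=O)N3CCNCC3)cc3sccc32)cc1`: > 100000 nM, a limit
Compound 3 `COc1ccc(Cn2c(C(=O)N3CCC(C(=O)NCc4ccccc4)CC3)cc3sccc32)cc1`: > 100000 nM, a limit

All three entries come from an ADME assay on HEK-293T cells (Homo sapiens) for cytotoxicity, read by luminescence, with a stated time of 24 h (a higher number here means that more compound is tolerated, a lower number that less compound is tolerated), and none of them is a measured number. Compound 3 gives only a limit, > 100000 nM. The series as a whole offers (the limit of > 100000 nM in this assay, at which 3 of the 3 values shown sit), so compound 3 cannot be placed above or below the other two.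

The next compound, compound 4 `COc1ccc(Cn2c(C(=O)N3CCC(C(=O)NC4CC4)CC3)cc3sccc32)cc1`, keeps the shared core and changes one group: cyclopropyl in place of benzyl on an amide-type nitrogen. In words, this is cyclopropyl in place of benzyl on an amide-type nitrogen.

Within the data shown here, the only measured step available for comparison lies elsewhere in the molecule and is a step that the two limits leave unreadable from compound 1 to compound 2. Among the measured compounds shown here, it supplies no size to carry over, and no measured step covers this exchange of groups. The expectation therefore rests on compound 3, with its limit of > 100000 nM. No step beyond the usual scatter is expected in this assay, in either direction, and a report of only a limit is the likely outcome. The expected change is a number no higher from compound 3 to compound 4 (the limit leaves the size open). The estimate for compound 4 is 100000 nM, with an expected range from 50000 nM to 200000 nM.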

Compound 4, half-maximal cytotoxic concentration: 21400 nM
For compound 4 the middle estimate is 4.7-fold (0.67 log units) above the measured one, outside the stated range (below it).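

In this assay, among these compounds, cyclopropyl in place of benzyl on an amide-type nitrogen gives an at least 4.6-fold lower number from compound 3 to compound 4 (0.66 log units; beyond the scatter), so this position can alter how much compound the cells tolerate, something the earlier compounds could not show, since their one step cannot be read. The change takes away a six-membered aromatic ring of carbon only and brings in a three-membered non-aromatic ring of carbon only, and the compound with the smaller group, 3 heavy atoms against 7, is the less tolerated of the pair. Compound 4 is thus the only compound shown that gives a measured number rather than a limit: the limit of > 100000 nM in this assay, at which 3 of the 4 values shown sit.

Going by these compounds, with a single exchange at this nitrogen, it stays open whether the loss of the aromatic ring or the cyclopropyl ring itself goes with the lower number, and how a cyclobutyl or an isopropyl group on the same nitrogen would read in this assay. On these data alone, the full size of the step also stays open, as compound 3 gives > 100000 nM, which is a limit.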